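A few compounds are considered here, and "the series" means these few. Any claim that something is new, unique, unknown or untested is made for them only; others in the source may bear on it.

Measured so far in an assay for positive allosteric modulation of metabotropic glutamate receptor 3 (Rattus norvegicus); a higher number here means that more compound is needed for the effect, a lower number that less compound is needed:
compound 1 `Cc1ncc(OCCCCOc2ccc(C(=O)CC(C)(C)C)c(O)c2C)cc1C(=O)O`; compound 1 gives 79 nM.
compound 2 `COc1ccc(C(=O)O)cc1OC[C@@H](C)Oc1ccc(C(=O)CC(C)(C)C)c(O)c1C`; compound 2 gives 806 nM.
compound 3 `Cc1ccc(OC[C@H](C)COc2ccc(C(=O)CC(C)(C)C)c(O)c2C)cc1C(=O)O`; compound 3 gives only a limit of the assay, > 10000 nM.

Compound 3 thus stands apart from the other two: its value is a limit and not a number, as noted in the limit of > 10000 nM in this assay, at which 1 of the 3 values shown sits, whereas compound 1 and compound 2 each give a number in this assay. Going by the values given here, no pair among the three compounds differs in a single place, so no measured step is available to calibrate the next change.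

Compound 4 `Cc1c(OC[C@@H](C)COc2ccc(C(=O)O)c(F)c2)ccc(C(=O)CC(C)(C)C)c1O` remains to be measured in this assay. Relative to compound 3 the change is 4-carboxy-3-fluorophenyl in place of 3-carboxy-4-methylphenyl on an oxygen on a saturated carbon. Among the compounds with values here, since compound 3 sits at a limit, the step from compound 3 to compound 4 can only be expected as a move back toward a measured value, or as none at all, and the data give no measured step to fix its size. The working expectation is that compound 4 gives 4000 nM in this assay, within a range of 800 nM to 10000 nM. The step this estimate implies is an at least 2.5-fold lower number from compound 3 to compound 4 (0.39 log units; beyond the scatter), and it is an estimate, not a measurement.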

Compound 4, half-maximal effective concentration: 1090 nM
Compound 4: the middle estimate sits 3.7-fold (0.56 log units) above what was measured; low and high end bracket the measured number.
By their numbers in this assay, from the lowest: compound 1; then compounds 2 and 4 (each within the scatter of the next). At a limit, above all of these: compound 3.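

In this assay, the aryl group on an oxygen on a saturated carbon responds to change: 4-carboxy-3-fluorophenyl in place of 3-carboxy-4-methylphenyl gives an at least 9.1-fold lower number from compound 3 to compound 4 (0.96 log units; beyond the scatter). Going by these compounds alone, this is the first step that can be read, and it shows that swapping this one group, with the rest of the molecule unchanged, is enough to bring a compound from a limit of the assay to a measured number. The size of the step remains a lower bound, since one of its ends is a limit: the limit of > 10000 nM in this assay, at which 1 of the 4 values shown sits.

Going by these compounds, the change replaces the methyl with a fluorine and moves the carboxylic acid in one step, so it remains open which of these carries the effect. Also open, on these data alone, is whether a tetrazole or a primary amide in place of the carboxylic acid would keep a measured number in this assay.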